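Halogen swap on the pendant ring: compound 3 to compound 4

The source may hold more compounds than are shown below. What is called first, only, known or untested is meant among the compounds shown, and "the series" means these compounds.

Measured in a functional assay on CHO cells for agonist activity at adenosine receptor A1 (Homo sapiens), read by fluorescence and ERK phosphorylation, with stated times of 30 min and 1.5 h, tested at 3 uM; a lower number here means a weaker effect, a higher number a stronger effect of the compound at the concentration tested:
Compound 1 `Nc1scc(-c2ccc(F)cc2)c1C(=O)c1ccc(Cl)cc1` gives 62%.
Compound 2 `Nc1scc(-c2cccc(Cl)c2)c1C(=O)c1ccc(Cl)cc1` gives 58%.
Compound 3 `Nc1scc(-c2ccc(Cl)cc2)c1C(=O)c1ccc(Cl)cc1` gives 50%.

Compound 3 carries the lowest of the three numbers in this assay, though a number 8 percentage points lower from compound 2 to compound 3 (within the scatter) stays within the scatter and only a number 12 percentage points lower from compound 1 to compound 3 (beyond the scatter) lies beyond it. Compound 4 `Nc1scc(-c2ccc(Br)cc2)c1C(=O)c1ccc(Cl)cc1` differs from compound 3 by bromo in place of chloro on an aromatic carbon. Within the data shown here, the one step that bears on this is a number 12 percentage points lower from compound 1 to compound 3 (beyond the scatter), the sole halogen-for-halogen exchange at that place; the other two steps, a number 4 percentage points lower from compound 1 to compound 2 (within the scatter) and a number 8 percentage points lower from compound 2 to compound 3 (within the scatter), move the chlorine rather than exchange it and stay within the scatter. The expected step of a number 5 percentage points lower from compound 3 to compound 4 (within the scatter) is therefore small, if anything downward, and may not exceed the scatter. Compound 4 is estimated at 45% in this assay, within 30% to 60%.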

Compound 4, a percentage reported as activity, at one concentration (the size of the read-out at that concentration, not a potency): 45%
For compound 4 middle estimate and measured number coincide at the digits printed, and the stated range covers the measured number.
By their numbers in this assay, from the lowest: compounds 4, 3, 2 and 1 (each within the scatter of the next, the first and the last beyond it).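

In this assay, bromo in place of chloro gives a number 5 percentage points lower from compound 3 to compound 4 (within the scatter), so this exchange alone is not resolved. Bromo in place of fluoro gives a number 17 percentage points lower from compound 1 to compound 4 (beyond the scatter), and 4-bromophenyl in place of 3-chlorophenyl gives a number 13 percentage points lower from compound 2 to compound 4 (beyond the scatter); both gaps lie beyond the scatter, whereas chloro at this place left only its gap to compound 1 beyond it. No measurement at hand accounts for these steps.

Open, as far as these compounds go, is how iodo, methyl, methoxy or an amine would read at this place. The single concentration also leaves potency across the series unresolved.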